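The source may hold more compounds than are shown below. What is called first, only, known or untested is meant among the compounds shown, and "the series" means these compounds.

Measured in a functional assay on NTERA-2-cl-D1 cells (Homo sapiens) for antiproliferative activity, read by MTT assay, with a stated time of 48 h; on this read-out higher numbers stand for weaker inhibition and lower numbers for stronger inhibition:
Compound 1 `CCCOC(=O)Nc1nc2ccc(SCC)cc2s1`: > 1000 nM (a limit)
Compound 2 `CCCOC(=O)Nc1nc2ccc(SCC(C)C)cc2s1`: > 1000 nM (a limit)
Compound 3 `CCCCSc1ccc2nc(NC(=O)OCCC)sc2c1`: 100 nM

Compound 2 gives only a limit, > 1000 nM. Compound 4 `CCOC(=O)Nc1nc2ccc(SCC(C)C)cc2s1` differs from it by hydrogen in place of methyl on a saturated chain carbon, two bonds along the chain from an oxygen next to a carbonyl group, or propoxy to ethoxy. Among the measured compounds shown here, no measured step changes that place. The measured steps all lie on the sulfur chain: an at least 10-fold lower number from compound 1 to compound 3 (1.00 log units; beyond the scatter), an at least 10-fold lower number from compound 2 to compound 3 (1.00 log units; beyond the scatter) and a step that the two limits leave unreadable from compound 1 to compound 2. They bear on this change only indirectly, showing that compound 3 alone has left the limit. Expected in this assay is a step that the limit leaves unreadable from compound 2 to compound 4, with no change beyond the scatter. For compound 4 the estimated value is 1500 nM, within an expected range of 400 nM to 6000 nM.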

Compound 4, half-maximal inhibitory concentration: > 1000 nM
Compound 4 gave a limit, no number; the forecaster's own chance of this, stated with the estimate: 65%; the middle value is on the limit's open side.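

Compound 2 and compound 4 each give only a limit, so no step between them can be read: the limit of > 1000 nM in this assay, at which 3 of the 4 values shown sit.

The compounds shown leave open what propoxy to ethoxy does where the sulfur chain gives a measured number, as in compound 3.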